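Replacing the benzamide arm with a pyridine: a solubility outlook

The compounds below may be only part of what the source reports. "The series", "measured", "known", "first", "only" and "open" are said of these compounds alone.

Two compounds with the shared core carrying a nitrile and a trifluoromethyl group have been measured in a physicochemical assay for solubility; on this read-out lower numbers stand for lower solubility and higher numbers for higher solubility. Compound 1 `CNC(=O)c1ccc(Cn2c(=O)n(-c3ccc(C#N)c(C(F)(F)F)c3)c3ccccc32)cc1F` gives 9900 nM, the higher of the two numbers. Compound 2 `CNC(=O)c1ccc(-c2ccc3c(c2)C(C)(C)C(=O)N3c2ccc(C#N)c(C(F)(F)F)c2)cc1F`, built around a different ring system, gives 6250 nM; its number is within the scatter of that of compound 1, so the two are not told apart on this assay.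

Compound 3 `N#Cc1ccc(-n2c(=O)n(Cc3ccccn3)c3ccccc32)cc1C(F)(F)F` has not yet been measured. It differs from compound 1 in one place: pyridin-2-yl in place of 3-fluoro-4-(methylcarbamoyl)phenyl on a saturated chain carbon bound to an aromatic nitrogen. Among the measured compounds shown here, no step between measured compounds involves this kind of change, so its effect on this assay is not known from the present set. The change removes the only hydrogen-bond donor of that arm while keeping one acceptor, and the molecule becomes smaller.

Compound 3 is expected to give 8000 nM, within a range from 2500 nM to 25000 nM. The step of a 1.2-fold lower number from compound 1 to compound 3 (0.09 log units; within the scatter) is estimated to be no larger than the usual scatter, with no firm direction.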

Compound 3, solubility: 12000 nM
Compound 3: the middle estimate sits 1.5-fold (0.18 log units) below what was measured; the measured number falls inside the stated range.
By their numbers in this assay, from the lowest: compounds 2, 1 and 3 (each within the scatter of the next).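

Among the compounds shown here, at the saturated chain carbon bound to an aromatic nitrogen, this is the first single change that can be read in this assay: pyridin-2-yl in place of 3-fluoro-4-(methylcarbamoyl)phenyl gives a 1.2-fold higher number from compound 1 to compound 3 (0.08 log units; within the scatter). On this read-out, compound 3 is therefore not told apart from compound 1, even though the entering group has fewer heavy atoms than the group that leaves and, unlike that group, has no hydrogen-bond donor. No measurement in hand offers an explanation for this outcome.

The swap changes the ring, the fluorine and the methylcarbamoyl group all at once, so the part each plays in this assay stays unresolved, and a plain phenyl, a pyridin-3-yl or a pyridin-4-yl on the same chain carbon would begin to separate them. From the compounds shown here alone, it also remains open whether a group of another kind at this place, such as a carboxylic acid or an amine, would give a step beyond the scatter, and whether pyridin-2-yl would behave the same way on the core of compound 2.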